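The compounds below may be only part of what the source reports. "The series", "measured", "known", "first", "only" and "open" are said of these compounds alone.

Notes on the series in a functional assay; a lower number here means a stronger inhibitor, a higher number a weaker inhibitor. Compound 1 `CC(C)=CCOc1ccc2c(c1)OC(c1ccc(F)cc1)CC2=O` gives 7320 nM in this assay. Compound 2 `CC(C)=CCOc1ccc2c(c1)OC(c1ccccc1Br)CC2=O` gives 3180 nM; the change of 2-bromophenyl in place of 4-fluorophenyl on a saturated ring carbon gives a 2.3-fold lower number from compound 1 to compound 2 (0.36 log units; beyond the scatter). Compound 3 `CC(C)=CCOc1cc(O)c2c(c1)OC(c1ccc(F)cc1)CC2=O` gives 6060 nM; the hydroxy in place of hydrogen on an aromatic carbon gives a 1.2-fold lower number from compound 1 to compound 3 (0.08 log units; within the scatter). Compound 3 is thus not separated beyond the scatter from either compound 1 or compound 2; the three numbers are close.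

Compound 4 `COc1ccc(C2CC(=O)c3c(O)cc(OCC=C(C)C)cc3O2)cc1` differs from compound 3 by methoxy in place of fluoro on an aromatic carbon. Going by the values given here, no measured step of this kind exists. Among the compounds with values here, the only step at the same part of the structure is the one from compound 1 to compound 2, which moved this assay by only a modest amount, and that step swaps a different group at a different place on the ring. On the numbers shown, a change at the phenyl group has not moved this assay far, so a small step is expected for compound 4, possibly none beyond the scatter, with a slight lean toward a lower number: a 1.2-fold lower number from compound 3 to compound 4 (0.08 log units; within the scatter). Compound 4 is therefore estimated at 5000 nM, within the range 2000 nM to 14000 nM.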

Compound 4, half-maximal inhibitory concentration: 5080 nM
For compound 4 the middle estimate is 1.0-fold (0.01 log units) below the measured one, within the range that was stated.
By their numbers in this assay, from the lowest: compounds 2, 4, 3 and 1 (each within the scatter of the next, the first and the last beyond it).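

In this assay, the exchange of fluoro for methoxy on an aromatic carbon, para to a large group, gives a 1.2-fold lower number from compound 3 to compound 4 (0.08 log units; within the scatter), so 4-fluorophenyl and 4-methoxyphenyl are not separated in this pair, although the methoxy adds a heavy atom and a hydrogen-bond acceptor. Going by these compounds alone, this is the first reading of a change at this position alone: the only earlier step on the phenyl group, a 2.3-fold lower number from compound 1 to compound 2 (0.36 log units; beyond the scatter), replaced 4-fluorophenyl with 2-bromophenyl and so changed both the group and its place on the ring. Nothing available bears on why this step stays within the scatter.

Open, from the compounds shown here alone, is whether an amine or a carboxylic acid at this position on the phenyl ring would give a step beyond the scatter, and whether a longer chain than methoxy, such as butoxy, would do the same. Also open, going by these compounds, is whether the exchange of fluoro for methoxy reads the same on the core of compound 1, which lacks the hydroxy of compound 3.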